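Cyclohexylamino in place of nitrofuran on the carbonyl carbon

A few compounds are considered here, and "the series" means these few. Any claim that something is new, unique, unknown or untested is made for them only; others in the source may bear on it.

Measured compounds:
Compound 1 `O=C(c1cc(Cl)nc(Cl)c1)N1CCc2cc(S(=O)(=O)N3C[C@H](c4ccccc4)NC3=O)ccc21`: 700 nM
Compound 2 `O=C(c1cccs1)N1CCc2cc(S(=O)(=O)N3C[C@H](c4ccccc4)NC3=O)ccc21`: 20 nM
Compound 3 `O=C(c1ccc([N+](=O)[O-])o1)N1CCc2cc(S(=O)(=O)N3C[C@H](c4ccccc4)NC3=O)ccc21`: 950 nM

In a functional assay on NCI-H460 cells (Homo sapiens) for inhibition (a higher number here means a weaker inhibitor of growth, a lower number a stronger inhibitor of growth), compound 3 gives the highest of the three numbers; compound 1 sits within the scatter of it, while compound 2 lies far off, as shown by a 48-fold higher number from compound 2 to compound 3 (1.68 log units; beyond the scatter). Compound 4 `O=C(NC1CCCCC1)N1CCc2cc(S(=O)(=O)N3C[C@H](c4ccccc4)NC3=O)ccc21` differs from compound 3 in one place: cyclohexylamino in place of 5-nitrofuran-2-yl on a carbonyl carbon. For the measured compounds named here, no measured step covers this change. The group on the carbonyl carbon does move the number strongly, as seen in a 35-fold lower number from compound 1 to compound 2 (1.54 log units; beyond the scatter) and a 48-fold higher number from compound 2 to compound 3 (1.68 log units; beyond the scatter), so a change of any size is possible. The step is expected to be a 2.4-fold lower number from compound 3 to compound 4 (0.38 log units; beyond the scatter) in this assay, with wide uncertainty. Compound 4 is therefore estimated at 400 nM, in a range from 60 nM to 2500 nM.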

Compound 4, concentration for 50% growth inhibition: 80 nM
Compound 4: the middle estimate sits 5.0-fold (0.70 log units) above what was measured; the measured number falls inside the stated range.
By their numbers in this assay, from the lowest: compound 2; then compound 4; then compounds 1 and 3 (each within the scatter of the next).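

In this assay, the position on the carbonyl carbon accepts a non-aromatic group joined through nitrogen, with a 12-fold lower number from compound 3 to compound 4 (1.07 log units; beyond the scatter) and an 8.8-fold lower number from compound 1 to compound 4 (0.94 log units; beyond the scatter), although a 4.0-fold higher number from compound 2 to compound 4 (0.60 log units; beyond the scatter) leaves the thiophen-2-yl compound with the lower number. An aromatic ring on this carbonyl carbon is therefore not needed for a low number, and the cyclohexylamino compound falls among the aromatic ones rather than beyond them. Nothing available explains these differences. From the compounds shown here alone, it remains open whether the nitrogen of cyclohexylamino matters, which a cyclohexyl group on the carbonyl carbon would test. Going by these compounds, it is also open how a phenylamino or methylamino group would compare.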